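Methoxy removal on the fused ring of compound 1

The compounds below may be only part of what the source reports. "The series", "measured", "known", "first", "only" and "open" are said of these compounds alone.

Compound 1 `COc1ccc2c(c1)C/C(=C\c1cc(-c3cc(OC)c(OC)c(OC)c3)n[nH]1)C2=O` gives 2100 nM in a functional assay on MCF7 cells (Homo sapiens) for inhibition, read by MTT assay, with a stated time of 48 h (on this read-out higher numbers stand for weaker inhibition and lower numbers for stronger inhibition), which places it at the upper end of the three measured numbers. Compound 3 `COc1cc2c(cc1OC)C(=O)/C(=C/c1cc(-c3cc(OC)c(OC)c(OC)c3)n[nH]1)C2` gives 2000 nM, and the step of a 1.1-fold lower number from compound 1 to compound 3 (0.02 log units; within the scatter) stays within the scatter. For the measured compounds named here, compound 2 `COc1ccc(C(=O)/C=C/c2cc(-c3cc(OC)c(OC)c(OC)c3)n[nH]2)cc1`, an open-chain analogue with no fused ring, gives 810 nM, a lower number beyond the scatter against compound 1; no single-point step connects these two, so the two values are simply set side by side.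

Compound 4 `COc1cc(-c2cc(/C=C3\Cc4ccccc4C3=O)[nH]n2)cc(OC)c1OC` has not yet been measured. It differs from compound 1 by hydrogen in place of methoxy on an aromatic carbon. Going by the values given here, the one measured step that bears on this change is the reverse operation, adding a methoxy on the same fused system, and it was a 1.1-fold lower number from compound 1 to compound 3 (0.02 log units; within the scatter), within the scatter. Compounds 1 and 3 show that gaining or losing a methoxy on this fused ring did not move this assay. The step from compound 1 to compound 4 is therefore expected to be a 1.1-fold higher number from compound 1 to compound 4 (0.04 log units; within the scatter), with no direction beyond the scatter. Compound 4 is estimated at 2300 nM, within a range of 1000 nM to 5500 nM in this assay.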

Compound 4, half-maximal inhibitory concentration: 4800 nM
Beside the measured number, compound 4's estimate is 2.1-fold (0.32 log units) below it, within the range that was stated.
By their numbers in this assay, from the lowest: compound 2; then compounds 3 and 1 (each within the scatter of the next); then compound 4.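

Removing the methoxy from the fused ring has a measurable effect in this assay, with a 2.3-fold higher number from compound 1 to compound 4 (0.36 log units; beyond the scatter), although the size of this step is modest. The earlier step, a 1.1-fold lower number from compound 1 to compound 3 (0.02 log units; within the scatter), added a further methoxy to compound 1 and stayed within the scatter, so it did not show that the methoxy already present in compound 1 contributes to the read-out; the two steps together show that methoxy changes on this fused ring do not all behave alike. No measurement shown here accounts for the higher number.

The compounds shown leave open whether a hydroxyl, an ethoxy or an amine on this aromatic carbon would give a number like that of compound 1 or one like that of compound 4. They also leave open whether the same change would matter on the methoxyphenyl ring of the open-chain compound 2.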